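A few compounds are considered here, and "the series" means these few. Any claim that something is new, unique, unknown or untested is made for them only; others in the source may bear on it.

Working notes on the series. Within the data shown here, compound 1 `CC1=NN(c2cccc(Cl)c2)C(=O)C12C=CC(=O)C=C2c1ccc(C)cc1` is the one member with a number: in a functional assay on HCT-116 cells (Homo sapiens) for antiproliferative activity, read by CCK-8 assay, with a stated time of 72 h (on this read-out lower numbers stand for stronger inhibition and higher numbers for weaker inhibition), compound 1 gives 2400 nM. Compound 2 `CC1=NN(c2ccc(Br)cc2)C(=O)C12C=CC(=O)C=C2c1ccccc1` and compound 3 `CC1=NN(c2ccc(Cl)cc2)C(=O)C12C=CC(=O)C=C2c1ccccc1` share the core of compound 1 with other groups. In this assay compound 2 reaches only > 100000 nM, a limit of the assay and not a number. Compound 3 likewise gives only > 100000 nM, again a limit. Compound 3 differs from compound 2 by chloro in place of bromo on an aromatic carbon, and the step that the two limits leave unreadable from compound 2 to compound 3 cannot be sized, as the limit of > 100000 nM in this assay, at which 2 of the 3 values shown sit, holds both ends. Compound 3 therefore stands at the limit, and its gap to compound 1 is known only as a number against a limit.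

Compound 4 `CC1=NN(c2cccc(Cl)c2)C(=O)C12C=CC(=O)C=C2c1ccccc1` arises from compound 3 by 3-chlorophenyl in place of 4-chlorophenyl on an amide-type nitrogen in a ring. Among the measured compounds shown here, no measured step isolates this change; compound 1 also carries 3-chlorophenyl on the amide-type nitrogen in a ring, but differs from compound 4 in a second place, so its value is only a loose pointer. The expectation for compound 4 is 20000 nM, in a range from 3000 nM to 150000 nM, resting on compound 1 at 2400 nM and on where compound 3 stands. The step expected for compound 4 is an at least 5.0-fold lower number from compound 3 to compound 4 (0.69 log units; beyond the scatter), a gain in inhibition, with a real chance that only a limit is returned.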

Compound 4, half-maximal inhibitory concentration: 7000 nM
Compound 4: the middle estimate sits 2.9-fold (0.46 log units) above what was measured, and the stated range covers the measured number.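

In this assay, 3-chlorophenyl in place of 4-chlorophenyl on the amide-type nitrogen in a ring gives an at least 14-fold lower number from compound 3 to compound 4 (1.15 log units; beyond the scatter), the first readable effect at this position, and since the two compounds have the same atoms, the place of the chlorine on the phenyl ring alone separates them. The same holds against the bromo analogue, with 3-chlorophenyl in place of 4-bromophenyl giving an at least 14-fold lower number from compound 2 to compound 4 (1.15 log units; beyond the scatter), and both steps are open-ended because each starts from a limit and not a number: the limit of > 100000 nM in this assay, at which 2 of the 4 values shown sit. With 3-chlorophenyl held fixed, hydrogen in place of methyl on an aromatic carbon gives a 2.9-fold higher number from compound 1 to compound 4 (0.46 log units; beyond the scatter), so the methyl is not needed for a measurable number in this assay, though its loss is a step beyond the scatter.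

From the compounds shown here alone, the step between the bromo and chloro compounds cannot be read, so the effect of the halogen at this position stays unknown. Also open, going by these compounds, is whether an amine, a methoxy group or a carboxylic acid in place of the chlorine of the 3-chlorophenyl group would keep a measurable number in this assay.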